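Swapping the Aryl Substituent: Cytotoxicity Steady So Far

A few compounds are considered here, and "the series" means these few. Any claim that something is new, unique, unknown or untested is made for them only; others in the source may bear on it.

Three compounds have been measured in an ADME assay on L02 cells (Homo sapiens) for cytotoxicity, read by MTT assay, with a stated time of 24 h; on this read-out lower numbers stand for stronger inhibition and higher numbers for weaker inhibition:
- compound 1 `Cc1ccc(S(=O)(=O)N2C/C(=C\c3cccc(F)c3)C(=O)/C(=C/c3cccc(F)c3)C2)cc1` gives 15700 nM
- compound 2 `O=C1/C(=C/c2cccc(F)c2)CN(S(=O)(=O)c2ccc(O[N+](=O)[O-])cc2)C/C1=C\c1cccc(F)c1` gives 10700 nM
- compound 3 `O=C1/C(=C/c2cccc(F)c2)CN(S(=O)(=O)c2ccc(Cl)cc2)C/C1=C\c1cccc(F)c1` gives 15700 nM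

All three share one core and differ only in the group on the aromatic carbon of the sulfonyl-bearing ring. Compound 3 stands level with compound 1 at the digits shown, and together they hold the highest of the three numbers; compound 2 lies nearest below, but the gap is within the scatter. The steps among them are all small: a 1.5-fold lower number from compound 1 to compound 2 (0.17 log units; within the scatter), no change at the digits printed from compound 1 to compound 3 (within the scatter) and a 1.5-fold higher number from compound 2 to compound 3 (0.17 log units; within the scatter). None of these changes moved the number beyond what repeated measurements would scatter.

Compound 4 `CC(=O)Nc1ccc(S(=O)(=O)N2C/C(=C\c3cccc(F)c3)C(=O)/C(=C/c3cccc(F)c3)C2)cc1` continues the same kind of swap: acetamido in place of chloro on an aromatic carbon. The three measured steps bear directly on it, since each also exchanged the group at this position, and each stayed within the scatter. By that record, the step in this assay from compound 3 to compound 4 is expected to be no larger than the scatter, with no clear direction. Compound 4 is therefore estimated at 14000 nM, with a range from 7000 nM to 28000 nM, which corresponds to an expected step of a 1.1-fold lower number from compound 3 to compound 4 (0.05 log units; within the scatter).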

Compound 4, half-maximal inhibitory concentration: 17500 nM
Beside the measured number, compound 4's estimate is 1.3-fold (0.10 log units) below it, and the stated range covers the measured number.
By their numbers in this assay, from the lowest: compounds 2, 1, 3 and 4 (each within the scatter of the next).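

In this assay, the position on the aromatic ring para to a large group accepts a clearly bigger substituent without a change beyond the scatter: acetamido, with 4 heavy atoms, one hydrogen-bond donor and one hydrogen-bond acceptor, replaces a single chlorine atom (a 1.1-fold higher number from compound 3 to compound 4 (0.05 log units; within the scatter)). The exchanges for the other two groups read the same way (a 1.1-fold higher number from compound 1 to compound 4 (0.05 log units; within the scatter); a 1.6-fold higher number from compound 2 to compound 4 (0.21 log units; within the scatter)), so methyl, nitrooxy, chloro and acetamido all lie within the scatter of one another here, and the earlier flat record now extends to a group carrying an amide hydrogen and a carbonyl. Nothing available here offers an explanation for this flat result.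

As far as these compounds go, whether the flat record would survive a charged group at this position, such as a free amine or a carboxylic acid, or a much longer chain, remains open. Also open, from the compounds shown here alone, is whether the number would respond to changes elsewhere, for instance to the two fluorine-bearing rings of the shared core, since every compound here keeps those parts unchanged.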